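Chloro in Place of Fluoro: Estimating Compound 4

A few compounds are considered here, and "the series" means these few. Any claim that something is new, unique, unknown or untested is made for them only; others in the source may bear on it.

The study compares four compounds built on two related cores. Compound 1 `CCS(=O)(=O)Nc1cc(F)cc2c1CCCC2c1c[nH]cn1` carries fluoro and an (ethylsulfonyl)amino group; in an assay on isolated protein for binding affinity to Alpha-1A adrenergic receptor (Rattus norvegicus), read by radioligand binding (on this read-out higher numbers stand for weaker inhibition and lower numbers for stronger inhibition), compound 1 gives 83.2 nM. Compound 2 `CCS(=O)(=O)Nc1cc(Cl)cc2c1CCCC2c1c[nH]cn1` differs from compound 1 by chloro in place of fluoro on an aromatic carbon, and in this assay compound 2 gives 45.7 nM. The step measured was a 1.8-fold lower number from compound 1 to compound 2 (0.26 log units; within the scatter). Compound 3 `CS(=O)(=O)Nc1ccc(F)c2c1CCCC2c1c[nH]cn1` belongs to the second core, bearing a methanesulfonamido group; the difference between the two cores is not broken down here. In this assay compound 3 gives 309 nM. Compound 4 `CS(=O)(=O)Nc1ccc(Cl)c2c1CCCC2c1c[nH]cn1` has not yet been measured in this assay; it differs from compound 3 by chloro in place of fluoro on an aromatic carbon. This is the same kind of change as that from compound 1 to compound 2, though the surroundings differ: in compound 4 the chloro stands ortho to a fused ring, meta to a fused ring and para to a methanesulfonamido group, while in compound 2 it stands meta to a (ethylsulfonyl)amino group, meta to a fused ring and para to a fused ring. Resting on a 1.8-fold lower number from compound 1 to compound 2 (0.26 log units; within the scatter), compound 4 is expected to show a step of similar size, a 1.8-fold lower number from compound 3 to compound 4 (0.26 log units; within the scatter). Compound 4 is therefore estimated at 170 nM, expected to fall between 70 nM and 400 nM.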

Compound 4, inhibition constant: 447 nM
Compound 4: the middle estimate sits 2.6-fold (0.42 log units) below what was measured; the measured number lies above the stated range.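

In this assay, chloro in place of fluoro on the core of compound 3 gives a 1.4-fold higher number from compound 3 to compound 4 (0.16 log units; within the scatter). Set beside the earlier step, this one runs the other way on paper, yet the two do not differ by more than repeated measurements would allow: the same change on two cores in this assay, a 1.8-fold lower number (0.26 log units; within the scatter) from compound 1 to compound 2 and a 1.4-fold higher number (0.16 log units; within the scatter) from compound 3 to compound 4, 2.6-fold (0.42 log units) apart, within the scatter of two such steps. On these two pairs, then, the change stays within the scatter on each core, and nothing separates its effect on one core from its effect on the other, but two small steps do not prove that the effect is the same on both or that it would hold on any further core.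

The compounds shown leave open what other groups would do at this place on either core, such as a methyl, a methoxy or a nitrile in place of fluoro and chloro. They also leave open whether the step would hold with a longer chain on the sulfonyl group, or with the methanesulfonamido and (ethylsulfonyl)amino groups exchanged on a single core.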